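The source may hold more compounds than are shown below. What is called first, only, known or untested is meant among the compounds shown, and "the series" means these compounds.

Compound 1 `O=C(NCCCCn1cccn1)c1cccc(C2SCC(=O)N2c2cc(Br)ccn2)c1`: 105 nM
Compound 2 `O=C(NCCCCc1ccccc1)c1cccc(C2SCC(=O)N2c2cccc(-c3c[nH]nn3)c2)c1`: 110 nM

In a functional assay on HOS-TE85 cells (Homo sapiens) for inhibition, read by CCK-8 assay, with a stated time of 72 h (a lower number here means a stronger inhibitor, a higher number a weaker inhibitor), compound 1, at 105 nM, stands level with compound 2, the two values lying within the scatter of each other. Compound 3 `O=C(NCCCCn1cccn1)c1cccc(C2SCC(=O)N2c2ccncc2)c1` has pyridin-4-yl in place of 4-bromopyridin-2-yl on an amide-type nitrogen in a ring. Among the compounds with values here, no measured pair shows a change of this kind, so the expectation rests on judgement alone. In this assay a moderate step towards a weaker inhibitor is expected, a 3.3-fold higher number from compound 1 to compound 3 (0.52 log units; beyond the scatter). The estimated value for compound 3 is 350 nM, within a range from 110 nM to 1300 nM.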

Compound 3, half-maximal inhibitory concentration: > 1000 nM
Compound 3 gave a limit, no number; the forecaster's own chance of this, stated with the estimate: 5%; middle value at least 2.8-fold (0.45 log units) away from the limit.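

At the amide-type nitrogen in a ring, putting pyridin-4-yl in place of 4-bromopyridin-2-yl gives an at least 9.5-fold higher number from compound 1 to compound 3 (0.97 log units; beyond the scatter) in this assay. The result for compound 3 is a limit and not a number: the limit of > 1000 nM in this assay, at which 1 of the 3 values shown sits. This position therefore does not treat the two groups as interchangeable, although each is one six-membered aromatic ring with the same hydrogen-bond counts.

The step removes the bromine and changes the point of attachment together, so it does not separate the two. On these data alone, whether a pyridin-2-yl group carrying chlorine or methyl instead of bromine would keep the activity stays open.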